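Cytotoxicity notes on an acrylamide chromone series

The source may report more compounds than this note shows. Statements on the series, on what has been measured and on what is new or still open speak of the compounds shown alone.

Two members of this series have a reading in an ADME assay on HepG2 2.2.15 cells (Homo sapiens) for cytotoxicity, read by MTT assay, with stated times of 48 h and 9 days; on this read-out lower numbers stand for higher toxicity in this test and higher numbers for lower toxicity in this test. Compound 1 `COc1cccc(NC(=O)/C=C/c2coc3cc(OC)ccc3c2=O)c1` gives 1130000 nM in that assay. Compound 2 `COc1ccc(NC(=O)/C=C/c2coc3cc(O)ccc3c2=O)cc1` gives 976000 nM in this assay. Among the measured compounds shown here, nothing separates these two on the numbers alone: the values of compound 1 and compound 2 lie within the usual scatter of each other, so neither can be called the more or less toxic of the pair, and no step between them is recorded. Both sit at the weakly toxic end of this read-out.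

Compound 3 `COc1ccc2c(=O)c(/C=C/C(=O)Nc3ccc(F)cc3)coc2c1` has not yet been measured in this assay. It derives from compound 1 by one change, (4-fluorophenyl in place of 3-methoxyphenyl on an amide-type nitrogen). The shared core and the amide linkage are kept as in compound 1. With only two measured points, both at the same level, there is no basis for expecting a sizeable move in either direction; the expected step from compound 1 to compound 3 in this assay is estimated as a 1.1-fold lower number from compound 1 to compound 3 (0.05 log units; within the scatter), that is, none beyond the scatter.

On that footing compound 3 is expected to give about 1000000 nM in this assay, with a plausible range from 500000 nM to 2000000 nM.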

Compound 3, half-maximal cytotoxic concentration: 743000 nM
For compound 3 the middle estimate is 1.3-fold (0.13 log units) above the measured one, and the stated range covers the measured number.
By their numbers in this assay, from the lowest: compounds 3, 2 and 1 (each within the scatter of the next).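

In this assay, placing 4-fluorophenyl instead of 3-methoxyphenyl on the amide-type nitrogen gives a 1.5-fold lower number from compound 1 to compound 3 (0.18 log units; within the scatter), the first step recorded at this position in the series. The shared core and the amide linkage are held constant across this pair, so the exchange of these two aromatic groups, which differ in their substituent and in the place it occupies, produces no difference that can be told from the scatter. No measurement is available that would bear on the reasons for this result.

Going by these compounds, it remains open whether this position responds at all to groups of a different kind, such as an amine or a carboxylic acid on the aromatic ring, or a longer alkyl chain in place of the ring, any of which might give a step beyond the scatter. It is also unsettled whether methoxy and fluorine would behave alike at one and the same ring position, since this single step alters both the substituent and its location, and whether the same exchange would read the same way on a core carrying a hydroxyl group.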